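Ethyl in place of methyl on the sulfonamide of compound 3

This account rests on a few compounds, and the source may have more. Where it says the series, first, only, none or still open, it means among the compounds named here.

Measured so far:
Compound 1, `CCS(=O)(=O)Nc1ccc(NC(=O)c2cc(C(F)(F)F)cc(C(F)(F)F)c2)cc1OC`: > 250000 nM
Compound 2, `CCS(=O)(=O)Nc1ccc(NC(=O)c2cc(C(F)(F)F)cc(C(F)(F)F)c2)cc1Cl`: 64100 nM
Compound 3, `CS(=O)(=O)Nc1ccc(NC(=O)c2cc(C(F)(F)F)cc(C(F)(F)F)c2)cc1F`: 125000 nM

Of the compounds shown here, three share one core and have been tested in an ADME assay on RAW264.7 cells (Mus musculus) for cytotoxicity, read by MTT assay, with a stated time of 48 h; a higher number here means a weaker inhibitor, a lower number a stronger inhibitor. Compound 1 gives only a limit, (the limit of > 250000 nM in this assay, at which 1 of the 3 values shown sits), and no number. Compound 2 gives 64100 nM. Compound 3 gives the highest of the two numbers, 125000 nM, which lies within the scatter of compound 2.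

Within the data shown here, the single measured step, an at least 3.9-fold lower number from compound 1 to compound 2 (0.59 log units; beyond the scatter), concerns a change on the aromatic ring and says nothing directly about the sulfonyl chain. Compound 4, `CCS(=O)(=O)Nc1ccc(NC(=O)c2cc(C(F)(F)F)cc(C(F)(F)F)c2)cc1F`, differs from compound 3 by methyl in place of hydrogen on a saturated chain carbon bound to a sulfonyl sulfur. Compound 2 already carries this ethylsulfonyl group and sits within the scatter of compound 3, so no step beyond the scatter is expected from compound 3 to compound 4, that is a 1.3-fold lower number from compound 3 to compound 4 (0.10 log units; within the scatter). Compound 4 is therefore estimated at 100000 nM, in a range from 40000 nM to 250000 nM.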

Compound 4, half-maximal inhibitory concentration: > 250000 nM
Compound 4: only a limit was reported; the forecaster's own chance of this, stated with the estimate: 25%; at least 2.5-fold (0.39 log units) between middle value and limit.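

In this assay, compound 4 gives only a limit, as compound 1 does, so the step between these two cannot be read: the limit of > 250000 nM in this assay, at which 2 of the 4 values shown sit. The change from methyl to ethyl on the sulfonyl chain now has its first direct reading, an at least 2.0-fold higher number from compound 3 to compound 4 (0.30 log units; that floor lies within the scatter), so this change shows no drop in the number, but the floor of the step cannot separate it from no change at all. With the ethylsulfonyl group held constant, the aromatic carbon gains a second reading, an at least 3.9-fold higher number from compound 2 to compound 4 (0.59 log units; beyond the scatter), for fluoro in place of chloro.

The compounds shown leave open how a longer chain, such as propyl, on the sulfonyl group would read in this assay. They also leave open how an amine or a nitrile on that aromatic carbon would compare with chloro.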